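The source may hold more compounds than are shown below. What is called first, only, known or untested is meant among the compounds shown, and "the series" means these compounds.

Compound 1 `O=C(O)Cc1sc(-c2ccccc2)nc1-c1ccc(F)cc1` gives 860 nM.
Compound 2 `O=C(O)Cc1sc(Cc2ccc(Cl)cc2)nc1-c1ccccc1` gives 580 nM.

Both numbers come from an in vitro functional assay on HEK285-7 cells for antagonist activity at prostaglandin D2 receptor 2 (Homo sapiens), read by BRET and beta-arrestin recruitment; on this read-out higher numbers stand for weaker inhibition and lower numbers for stronger inhibition. Of the two, compound 2 has the lower one, yet its gap to compound 1 lies within the usual scatter, so the pair cannot be told apart. Compound 3 `COc1ccc(-c2nc(Cc3ccc(Cl)cc3)sc2CC(=O)O)cc1` differs from compound 2 in one place: methoxy in place of hydrogen on an aromatic carbon. Among the measured compounds shown here, no measured pair shows what this change does here, so the step of a 1.2-fold lower number from compound 2 to compound 3 (0.06 log units; within the scatter) is expected to stay within the scatter, with no clear direction. For compound 3 the expected value in this assay is 500 nM, with a range from 200 nM to 1500 nM.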

Compound 3, half-maximal inhibitory concentration: 850 nM
For compound 3 the middle estimate is 1.7-fold (0.23 log units) below the measured one, within the range that was stated.
By their numbers in this assay, from the lowest: compounds 2, 3 and 1 (each within the scatter of the next).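

Going from phenyl to 4-methoxyphenyl in this assay gives a 1.5-fold higher number from compound 2 to compound 3 (0.17 log units; within the scatter) and so shows no change that can be told from the scatter: this position para to a large group accepts methoxy with the read-out held. Among the compounds shown here, that rests on a single measured pair, the only one here for this change. Nothing measured here gives a reason for this result. From the compounds shown here alone, whether a hydroxyl, an amine or a longer chain such as ethoxy at this place would behave the same remains open, and so does whether methoxy would leave the read-out unmoved on the core of compound 1.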